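A Bromo Group Replaces the Dihydroxypropoxy Chain

This account rests on a few compounds, and the source may have more. Where it says the series, first, only, none or still open, it means among the compounds named here.

Compound 3 `COc1cc(OC)c2c(=O)cc(-c3ccc(OCC(O)CO)cc3)oc2c1` carries a 2,3-dihydroxypropoxy chain and stands lowest of the two numbers seen so far: in a functional assay (Homo sapiens) for antiproliferative activity, read by resazurin assay, with a stated time of 48 h, tested at 20 uM (on this read-out lower numbers stand for a weaker effect and higher numbers for a stronger effect at the one concentration tested), compound 3 gives 16%. Going by the values given here, compound 1 `COc1cc(OC)c2c(=O)cc(-c3ccc(OCCN4CCCC4=O)cc3)oc2c1` gives 33% in this assay, and the single step in this set, a number 17 percentage points lower from compound 1 to compound 3 (beyond the scatter), runs downward. Compound 2 `COc1cc(OC)c2c(=O)cc(-c3ccc(OCCCN)cc3)oc2c1` has no result in this assay: for compound 2 the entry reads "not determined" (no result reported). Compound 4 `COc1cc(OC)c2c(=O)cc(-c3ccc(Br)cc3)oc2c1` differs from compound 3 by bromo in place of 2,3-dihydroxypropoxy on an aromatic carbon. Among the compounds with values here, no measured step concerns a bromo group on the aromatic carbon; the only known step exchanged groups on a chain, so it offers no direct guide. Within the data shown here, compound 4 is therefore expected to land near the two known numbers, the step of a number 12 percentage points higher from compound 3 to compound 4 (beyond the scatter) being of uncertain direction, with an estimated value in this assay of 28%, between 5% and 60%.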

Compound 4, a percentage reported as inhibition, at one concentration (the size of the read-out at that concentration, not a potency): 22%
Estimate against measurement, compound 4: 6 percentage points above, within the range that was stated.
By their numbers in this assay, from the lowest: compounds 3 and 4 (each within the scatter of the next); then compound 1.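

With a number 6 percentage points higher from compound 3 to compound 4 (within the scatter) in this assay the 2,3-dihydroxypropoxy chain can give way to a single bromo on this aromatic carbon without a change beyond the scatter, even though the bromo has no hydrogen-bond donors or acceptors. With a number 11 percentage points lower from compound 1 to compound 4 (beyond the scatter) the 2-(2-oxopyrrolidin-1-yl)ethoxy chain stays ahead of the bromo at this position. Nothing given here accounts for either step.

Going by these compounds, whether a chloro group would read like the bromo remains open. So does whether a carboxylic acid or a longer chain ending in an amide would reach or pass compound 1 in this assay on this carbon.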